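The source may hold more compounds than are shown below. What is called first, only, known or untested is meant among the compounds shown, and "the series" means these compounds.

Compound 1, `Nc1cc(N)c2nc(-c3ccccc3)c(Oc3ccc(Cl)c(Cl)c3)nc2c1`, carries a phenyl group and a 3,4-dichlorophenoxy group on its shared core. In a functional assay on OVCAR-5 cells (Homo sapiens) for inhibition, read by sulforhodamine B assay, with a stated time of 48 h (a higher number here means that more compound is tolerated, a lower number that less compound is tolerated), compound 1 gives < 100000 nM, which is a limit of the measurement and not a number. Two other compounds have the same core. In this assay compound 2, `CCOC(=O)[C@H](CCC(=O)O)NC(=O)c1ccc(Oc2nc3cc(N)cc(N)c3nc2-c2ccccc2)cc1`, gives < 100000 nM, again only a limit. In this assay compound 3, `COc1ccc(CNc2nc3cc(N)cc(N)c3nc2-c2ccccc2)cc1`, gives < 100000 nM, also a limit. So compound 1 stands nowhere in particular among the numbers shown, since every result so far sits at the limit of < 100000 nM in this assay, at which 3 of the 3 values shown sit. Among the measured compounds shown here, no step between two measured compounds with a single difference is available. Compound 4, `Nc1cc(N)c2nc(-c3ccccc3)c(Sc3ccc(F)cc3)nc2c1`, is not yet measured; it differs from compound 1 by (4-fluorophenyl)sulfanyl in place of 3,4-dichlorophenoxy on an aromatic carbon. With every known value a limit, the step from compound 1 to compound 4 is expected to be small, roughly a step that the limit leaves unreadable from compound 1 to compound 4, with no clear direction beyond the scatter. For compound 4 the estimated value in this assay is 50000 nM, in the range 10000 nM to 100000 nM.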

Compound 4, concentration lethal to 50% of the cells: < 100000 nM
Compound 4 was reported as a limit (the forecaster's own chance of this, stated with the estimate: 70%); the middle value does not contradict the limit.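

In this assay compound 4 gives < 100000 nM as a limit and not a number. Among the compounds shown here, compound 1 is also known only as a limit, so no step between compound 1 and compound 4 can be read: the limit of < 100000 nM in this assay, at which 4 of the 4 values shown sit. The compounds shown leave open how their actual values compare.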